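Replacing a dimethoxyphenyl group with a nitrophenyl group

A few compounds are considered here, and "the series" means these few. Any claim that something is new, unique, unknown or untested is made for them only; others in the source may bear on it.

Compound 1 `COc1ccc(/C=C2\CN(C)C/C(=C\c3ccccc3F)C2=O)cc1` gives 18400 nM
Compound 2 `CN1C/C(=C\c2ccc(C#N)cc2)C(=O)/C(=C/c2ccccc2F)C1` gives 2670 nM
Compound 3 `COc1cc(/C=C2\CN(C)C/C(=C\c3cc(OC)c(OC)c(OC)c3)C2=O)cc(OC)c1` gives 3470 nM

In a functional assay on K562 cells (Homo sapiens) for cytotoxicity, read by MTT assay, with a stated time of 24 h (on this read-out higher numbers stand for weaker inhibition and lower numbers for stronger inhibition), compound 3 (3470 nM) lies within the usual scatter of compound 2 (2670 nM), so the two cannot be told apart. Compound 1 (18400 nM) stands clearly higher than both.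

Compound 4 `COc1cc(/C=C2\CN(C)C/C(=C\c3cccc([N+](=O)[O-])c3)C2=O)cc(OC)c1OC` differs from compound 3 in one place (3-nitrophenyl in place of 3,5-dimethoxyphenyl on a double-bonded chain carbon bound to a double-bonded ring carbon), with 3-nitrophenyl in place of 3,5-dimethoxyphenyl on a double-bonded chain carbon bound to a double-bonded ring carbon.

Among the compounds with values here, only one measured step bears on this change, and only loosely. In that step, a 6.9-fold lower number from compound 1 to compound 2 (0.84 log units; beyond the scatter) came with cyano in place of methoxy on an aromatic carbon. It was modest but beyond the scatter. Within the data shown here, no measured compound carries a nitro group, and the step belongs to a different pair of compounds, so it gives a direction more than a size. A smaller move in the same direction seems the cautious reading, and a result within the scatter would be no surprise. The expected change is a 2.3-fold lower number from compound 3 to compound 4 (0.36 log units; beyond the scatter) in this assay and it points to a lower number. For compound 4 the estimated value is 1500 nM with an expected range of 450 nM to 5000 nM.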

Compound 4, half-maximal inhibitory concentration: 4200 nM
Beside the measured number, compound 4's estimate is 2.8-fold (0.45 log units) below it; measured number inside the range.
By their numbers in this assay, from the lowest: compounds 2, 3 and 4 (each within the scatter of the next); then compound 1.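

On a double-bonded chain carbon bound to a double-bonded ring carbon, putting 3-nitrophenyl in place of 3,5-dimethoxyphenyl gives a 1.2-fold higher number from compound 3 to compound 4 (0.08 log units; within the scatter) in this assay, so the two compounds cannot be told apart on this read-out. Within the data shown here, this is the first measured change at this place, and it shows that a ring with two methoxy groups and a ring with one nitro group can be exchanged here without a detectable shift, whereas the only earlier step, a 6.9-fold lower number from compound 1 to compound 2 (0.84 log units; beyond the scatter), lay beyond the scatter but involved a different change in a different pair. Nothing among the data shown explains why this exchange leaves the two numbers indistinguishable.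

The compounds shown leave open whether a ring carrying an amine or a carboxylic acid, or a plain phenyl group, at this same place would move the number beyond the scatter. They also leave open whether 3-nitrophenyl would behave the same way in a compound whose other ring is the fluorine-bearing ring of compound 1 rather than the ring kept in compound 3 and compound 4.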